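Methylsulfanyl for methoxy on the shared core

This account rests on a few compounds, and the source may have more. Where it says the series, first, only, none or still open, it means among the compounds named here.

Measured so far in a functional assay on the whole organism with Rattus norvegicus as the target; a lower number here means that less compound is needed, a higher number that more compound is needed for the effect:
compound 1, `CCc1c(SC)nc2nc(-c3nnc(C)o3)cn2c1C`: 5 mg/kg
compound 2, `CCc1c(OC)nc2nc(-c3nc(C)cs3)cn2c1C`: > 50 mg/kg

Compound 2 stands only at a limit in this assay: its value of > 50 mg/kg is a limit of the assay and not a number, and it sits at the limit of > 50 mg/kg in this assay, at which 1 of the 2 values shown sits. Compound 1 in this assay gives 5 mg/kg, a number. Among the measured compounds shown here, the two compounds differ in two places, so nothing is counted between them; their values show only that compound 1 reaches a number where compound 2 does not.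

Compound 3, `CCc1c(SC)nc2nc(-c3nc(C)cs3)cn2c1C`, is not yet measured in this assay. It differs from compound 2 in one place: methylsulfanyl in place of methoxy on an aromatic carbon. Compound 3 thus carries the same methylsulfanyl group that compound 1 carries, and compound 1 gives 5 mg/kg.

A step beyond the scatter, toward a lower number, is expected, namely an at least 3.3-fold lower number from compound 2 to compound 3 (0.52 log units; beyond the scatter). Compound 3 is expected to give 15 mg/kg, with a range from 5 mg/kg to 50 mg/kg.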

Compound 3, minimum effective dose: > 50 mg/kg
Compound 3: only a limit was reported; the forecaster's own chance of this, stated with the estimate: 35%; at least 3.3-fold (0.52 log units) between middle value and limit.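

Methylsulfanyl in place of methoxy on the shared core does not by itself bring a number in this assay: compound 3 gives > 50 mg/kg, which is a limit of the assay and not a number. With methylsulfanyl held in place, 4-methyl-1,3-thiazol-2-yl in place of 5-methyl-1,3,4-oxadiazol-2-yl goes with an at least 10-fold higher number from compound 1 to compound 3 (1.00 log units; beyond the scatter), so among the compounds shown, the number belongs only to the compound carrying the 5-methyl-1,3,4-oxadiazol-2-yl group. The step for the methylsulfanyl change itself cannot be read, since both compounds sit at one limit: the limit of > 50 mg/kg in this assay, at which 2 of the 3 values shown sit.

The compounds shown do not tell whether methoxy alongside 5-methyl-1,3,4-oxadiazol-2-yl would also reach a number, so the contribution of methylsulfanyl with that group remains open. From the compounds shown here alone, how an amine or a longer chain at the methylsulfanyl position would read in this assay also remains open.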